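Carbamoyl substituent variation on the shared core

A few compounds are considered here, and "the series" means these few. Any claim that something is new, unique, unknown or untested is made for them only; others in the source may bear on it.

Measured compounds, in an assay (strain Wistar) for inhibition of Hormone-sensitive lipase (Rattus norvegicus), read by spectrophotometry; a higher number here means a weaker inhibitor, a lower number a stronger inhibitor:
- compound 1 `Cc1c(C(C)C)c(=O)on1C(=O)N(C)Cc1ccc(F)cc1`: 111 nM
- compound 2 `Cc1c(C(C)C)c(=O)on1C(=O)N(C)Cc1cccs1`: 2 nM
- compound 3 `Cc1c(C(C)C)c(=O)on1C(=O)N(C)CCC#N`: only a limit, > 1000 nM

Compound 3 stands at the weak end of the three numbers shown; its value is a limit of this assay, not a number (the limit of > 1000 nM in this assay, at which 1 of the 3 values shown sits). Both measured steps into compound 3 run the same way: an at least 9.0-fold higher number from compound 1 to compound 3 (0.95 log units; beyond the scatter) and an at least 500-fold higher number from compound 2 to compound 3 (2.69 log units; beyond the scatter), while a 56-fold lower number from compound 1 to compound 2 (1.74 log units; beyond the scatter) shows how much the two ring-bearing compounds differ from each other.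

Compound 4 `Cc1c(C(C)C)c(=O)on1C(=O)N1CCNCC1` is not yet measured. It differs from compound 3 as follows: piperazin-1-yl in place of (2-cyanoethyl)(methyl)amino on a carbonyl carbon. Within the data shown here, none of the measured steps touches the carbonyl carbon in this way; they only exchange the group on the saturated chain carbon. What they do show is that compound 3, which carries no aromatic ring, sits at the limit, and compound 4 likewise carries no aromatic ring. The expectation is therefore that compound 4 stays weak, with no step beyond the scatter, a step that the limit leaves unreadable from compound 3 to compound 4, and a fair chance that this assay again returns only a limit. Compound 4 is estimated at 2500 nM, ranging from 400 nM to 15000 nM.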

Compound 4, half-maximal inhibitory concentration: > 1000 nM
Compound 4: no number, only a limit; the forecaster's own chance of this, stated with the estimate: 60%; the middle value does not contradict the limit.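

In this assay compound 4 gives > 1000 nM, which is a limit and not a number. Among these compounds, compound 3 also stands only at a limit, so no step from compound 3 to compound 4 can be read: the limit of > 1000 nM in this assay, at which 2 of the 4 values shown sit. The compounds shown leave open whether piperazin-1-yl in place of (2-cyanoethyl)(methyl)amino on a carbonyl carbon changes inhibition at all.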